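Cyclopentyl for butyl on the imidazole nitrogen: tolerability notes

This account rests on a few compounds, and the source may have more. Where it says the series, first, only, none or still open, it means among the compounds named here.

Compound 1 `CCCCn1c(-c2ccc(OC)cc2)cnc1NC(=O)c1ccc(F)cc1` is the reference point of this pair. In a toxicity assay on THP-1 cells (Homo sapiens) for inhibition (a lower number here means that less compound is tolerated, a higher number that more compound is tolerated), compound 1 reaches only the assay limit of > 100000 nM, which is a limit and not a number. Compound 2 `COc1ccc2c(c1)nc(NC(=O)c1ccc(F)cc1)n2C` likewise stops at a limit, giving > 100000 nM in this assay. The evidence so far is the limit of > 100000 nM in this assay, at which 2 of the 2 values shown sit. Compound 3 `COc1ccc(-c2cnc(NC(=O)c3ccc(F)cc3)n2C2CCCC2)cc1` carries cyclopentyl in place of butyl on an aromatic nitrogen. Within the data shown here, no measured step bears on this change. The step that the limit leaves unreadable from compound 1 to compound 3 is expected to be none beyond the scatter, most probably ending again at a limit. Compound 3 is estimated at 120000 nM, within 40000 nM to 400000 nM.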

Compound 3, half-maximal cytotoxic concentration: > 100000 nM
Compound 3 gave a limit, no number; the forecaster's own chance of this, stated with the estimate: 85%; the middle value does not contradict the limit.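

Compound 1 and compound 3 both end at a limit, not a number, in this assay, and the step between them cannot be read. The compounds shown leave open whether butyl and cyclopentyl on the aromatic nitrogen differ in tolerated concentration.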